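The compounds below may be only part of what the source reports. "The series", "measured", "known", "first", "only" and "open" are said of these compounds alone.

Measured so far in a functional assay on CHO cells for agonist activity at Free fatty acid receptor 2 (Homo sapiens), read by cAMP accumulation; on this read-out higher numbers stand for weaker inhibition and lower numbers for stronger inhibition:
- compound 1 `CC(C)[C@H](C(=O)Nc1ccccn1)c1ccc(Cl)cc1`: 1400 nM
- compound 2 `CC(C)[C@H](C(=O)Nc1ncc[nH]1)c1ccc(Cl)cc1`: 20000 nM
- compound 3 `CC(C)[C@H](C(=O)Nc1ccon1)c1ccc(Cl)cc1`: 36000 nM

Compound 3 gives the highest of the three numbers in this assay. Its nearest neighbour is compound 2, and the gap a 1.8-fold higher number from compound 2 to compound 3 (0.26 log units; within the scatter) lies within the scatter. Its furthest neighbour is compound 1, with the large step of a 26-fold higher number from compound 1 to compound 3 (1.41 log units; beyond the scatter), matched by the similarly large step a 14-fold higher number from compound 1 to compound 2 (1.15 log units; beyond the scatter).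

Compound 4 `CC(C)[C@H](C(=O)Nc1cnns1)c1ccc(Cl)cc1` has not yet been measured. It differs from compound 3 in one place: 1,2,3-thiadiazol-5-yl in place of 1,2-oxazol-3-yl on an amide-type nitrogen. Going by the values given here, the steps that bear on this change are those in which a five-membered aromatic ring replaces pyridin-2-yl on the amide-type nitrogen, and the two measured examples of that kind sit close together, as a 1.8-fold higher number from compound 2 to compound 3 (0.26 log units; within the scatter) shows. Both five-membered rings gave weak inhibition, so another five-membered ring on the same nitrogen is expected to land in the same region, with no step beyond the scatter. Compound 4 is therefore estimated at 25000 nM, with a range from 8000 nM to 80000 nM, corresponding to an expected step of a 1.4-fold lower number from compound 3 to compound 4 (0.16 log units; within the scatter).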

Compound 4, half-maximal inhibitory concentration: 57000 nM
Compound 4: middle estimate off by 2.3-fold (0.36 log units), on the low side; low and high end bracket the measured number.
By their numbers in this assay, from the lowest: compound 1; then compounds 2, 3 and 4 (each within the scatter of the next, the first and the last beyond it).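

In this assay, a third five-membered ring on the amide-type nitrogen stays in the weak region: 1,2,3-thiadiazol-5-yl in place of 1,2-oxazol-3-yl leaves the two rings not told apart (a 1.6-fold higher number from compound 3 to compound 4 (0.20 log units; within the scatter)). Against 1H-imidazol-2-yl, the same ring gives the first step beyond the scatter among these five-membered rings, though only a modest one (a 2.9-fold higher number from compound 2 to compound 4 (0.45 log units; beyond the scatter)), while the gap to the pyridin-2-yl compound reaches its widest so far (a 41-fold higher number from compound 1 to compound 4 (1.61 log units; beyond the scatter)), leaving compound 1 alone at the low end of the four. No measurement shown here accounts for any of these differences.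

The compounds shown leave open whether another six-membered ring on the same nitrogen, such as pyrimidin-2-yl or phenyl, would keep a number close to that of compound 1. They also leave open what a methyl group on the pyridin-2-yl ring would do.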